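Predicting a sulfonamide on the pyrazole-linked aryl ring

The source may hold more compounds than are shown below. What is called first, only, known or untested is meant among the compounds shown, and "the series" means these compounds.

Compound 1, `CC(C)(C)c1cc(NC(=O)Nc2ccc(Cl)cc2)n(-c2ccc(C(F)(F)F)cc2)n1`, gives -0.6 degrees C in an assay on isolated protein for inhibition of serine/threonine-protein kinase 10 (Homo sapiens), read by thermal shift assay, tested at 10 uM; a lower number here means that the compound stabilises the target less, a higher number that the compound stabilises the target more against heat.
Compound 2, `CC(C)(C)c1cc(NC(=O)Nc2ccc(Cl)cc2)n(-c2ccc(OC(F)(F)F)cc2)n1`, gives 0 degrees C in this assay.
Compound 3, `CC(C)(C)c1cc(NC(=O)Nc2ccc(Cl)cc2)n(-c2ccc(N)cc2)n1`, gives 2 degrees C in this assay.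

Compound 3 holds the highest number of the three; the step of a number 2.0 degrees C higher from compound 2 to compound 3 (beyond the scatter) and the step of a number 2.6 degrees C higher from compound 1 to compound 3 (beyond the scatter) both lie beyond the scatter, whereas the step of a number 0.60 degrees C higher from compound 1 to compound 2 (within the scatter) does not. All three compounds share the same core and the same urea-linked chlorophenyl, and differ only in the group on the other aryl ring.

Compound 4, `CC(C)(C)c1cc(NC(=O)Nc2ccc(Cl)cc2)n(-c2ccc(NS(C)(=O)=O)cc2)n1`, is the next member. It differs from compound 3 by methylsulfonyl in place of hydrogen on a nitrogen on an aromatic ring. Within the data shown here, no measured pair shows this exact exchange, so the steps at that position are only indirect guides: two of them were modest and one was within the scatter, and all of them led to compound 3 rather than away from it. With nothing pointing clearly either way, compound 4 is expected to stay near compound 3, with a step of about a number 1.0 degrees C lower from compound 3 to compound 4 (within the scatter) that may fall within the scatter. The estimate for compound 4 is therefore 1 degrees C, in a range from -1 degrees C to 3 degrees C.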

Compound 4, shift of the target's melting temperature: 8.9 degrees C
For compound 4 the middle estimate is 7.9 degrees C below the measured one, and the stated range ends below it.
By their numbers in this assay, from the lowest: compounds 1 and 2 (each within the scatter of the next); then compound 3; then compound 4.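

In this assay, methylsulfonyl in place of hydrogen on the nitrogen gives a number 6.9 degrees C higher from compound 3 to compound 4 (beyond the scatter), so this nitrogen is a point at which one further substituent can move the number a long way, which the exchanges among the first three compounds could not reveal. Methanesulfonamido on the same aromatic carbon gives a number 8.9 degrees C higher from compound 2 to compound 4 (beyond the scatter) in place of trifluoromethoxy and a number 9.5 degrees C higher from compound 1 to compound 4 (beyond the scatter) in place of trifluoromethyl, both large steps, whereas amino in place of those two groups gave only modest ones. This single position therefore spans a far wider range of thermal stabilisation than the first three compounds showed, and compound 4 stands highest of the four, beyond the scatter from each of the others.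

Nothing available accounts for the size of this effect. The compounds shown leave open whether the same rise would follow with acetamido, which has a carbonyl in place of the sulfonyl, with a longer chain such as ethylsulfonyl, or with a methyl group on the sulfonamide nitrogen.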